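The source may hold more compounds than are shown below. What is called first, only, known or untested is meant among the compounds shown, and "the series" means these compounds.

Working notes on the urea series. Compound 1 `CN(C)C1(Cc2ccccc2)CCN(c2cc(C(F)(F)F)ccc2CNC(=O)NCc2ccc(NS(C)(=O)=O)c(F)c2)CC1` and compound 2 `CN(C)C1(Cc2ccccc2)CCN(c2cc(C(F)(F)F)ccc2CNC(=O)Nc2ccc(CO)c(F)c2)CC1` share the core and carry substituted phenyl groups on the urea nitrogen; in an assay on CHO cells for antagonist activity at transient receptor potential cation channel subfamily V member 1 (Homo sapiens), read by scintillation counting, with a stated time of 5 min, in the presence of a further agent that is not named here (a lower number here means that less compound is needed, a higher number that more compound is needed for the effect), compound 1 gives 85.9 nM, and in this assay compound 2 gives 81 nM, the two values lying within the usual scatter of each other. Compound 3 `CN(C)C1(Cc2ccccc2)CCN(c2cc(C(F)(F)F)ccc2CNC(=O)Nc2cccc3c(=O)[nH]ccc23)CC1` replaces that phenyl with a bicyclic lactam; in this assay compound 3 gives "not active" (no number reported), with no number reported, so it stands apart from compound 1 and compound 2 without a measurable gap. Compound 4 `CN(C)C1(Cc2ccccc2)CCN(c2cc(C(F)(F)F)ccc2CNC(=O)Nc2cccc3cnccc23)CC1` is not yet measured. It differs from compound 3 by a group of 10 heavy atoms (9 carbon, 1 nitrogen; one six-membered aromatic ring of carbon only, one six-membered aromatic ring with 1 hetero atom) in place of a group of 11 heavy atoms (9 carbon, 1 nitrogen, 1 oxygen; one six-membered aromatic ring of carbon only, one six-membered aromatic ring with 1 hetero atom), on an amide-type nitrogen. Within the data shown here, no step between measured compounds covers this change, and nothing in the measured set shows what the bicyclic group does once its carbonyl and amide hydrogen are gone. Compound 4 is therefore expected to move back toward a measurable value, but with wide uncertainty: the estimate for compound 4 in this assay is 600 nM, with a range from 100 nM to 6000 nM.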

Compound 4, half-maximal effective concentration: 8.8 nM
Beside the measured number, compound 4's estimate is 68-fold (1.83 log units) above it; the whole stated range lies above it.
By their numbers in this assay, from the lowest: compound 4; then compounds 2 and 1 (each within the scatter of the next).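

On the amide-type nitrogen, the bicyclic group is not excluded as such: in this assay compound 3 gives "not active" (no number reported) and compound 4 gives 8.8 nM, although no size can be read for that change with no number for compound 3. Isoquinolin-5-yl in place of 3-fluoro-4-(hydroxymethyl)phenyl gives a 9.2-fold lower number from compound 2 to compound 4 (0.96 log units; beyond the scatter), which shows that this place can respond to the choice of group beyond the scatter. Nothing measured here accounts for either result.

The carbonyl and the amide hydrogen leave together between compound 3 and compound 4, so the part played by each stays unresolved. Also open, as far as these compounds go, is how an amine or a carboxylic acid carried on the isoquinolin-5-yl group would read in this assay.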